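Shifting the benzyl substituent in the piperazine series

This account rests on a few compounds, and the source may have more. Where it says the series, first, only, none or still open, it means among the compounds named here.

Of the compounds shown here, two have been measured. Compound 1 `N#Cc1ccccc1COc1ccc(-c2cc(CN3CCN(Cc4ccc(C(F)(F)F)cc4)CC3)no2)cc1` gives 3500 nM in a functional assay on Mahlavu cells (Homo sapiens) for antiproliferative activity, read by sulforhodamine B assay, with a stated time of 72 h (on this read-out higher numbers stand for weaker inhibition and lower numbers for stronger inhibition), and compound 2 `N#Cc1cccc(COc2ccc(-c3cc(CN4CCN(Cc5ccc(C(F)(F)F)cc5)CC4)no3)cc2)c1` gives 10600 nM in the same assay, the higher of the two numbers. Among the measured compounds shown here, the only measured step, a 3.0-fold higher number from compound 1 to compound 2 (0.48 log units; beyond the scatter), concerns the position of the nitrile on the benzyloxy arm and leaves the other end of the molecule untouched.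

Compound 3 `N#Cc1cccc(COc2ccc(-c3cc(CN4CCN(Cc5ccccc5F)CC4)no3)cc2)c1` differs from compound 2 elsewhere: 2-fluorophenyl in place of 4-(trifluoromethyl)phenyl on a saturated chain carbon bound to an amine nitrogen in a ring. For the measured compounds named here, no measured step touches this part of the structure, so the step from compound 1 to compound 2 gives no direct guidance here, and the only anchor is the number of compound 2 itself. With nothing to indicate a direction, the step is expected to stay within the usual scatter, a 1.1-fold higher number from compound 2 to compound 3 (0.05 log units; within the scatter), although a change of either sign beyond it cannot be excluded on this evidence.

Compound 3 is therefore estimated at 12000 nM in this assay, with a plausible range from 4000 nM to 36000 nM.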

Compound 3, half-maximal inhibitory concentration: 2300 nM
Estimate against measurement, compound 3: 5.2-fold (0.72 log units) above; the whole stated range lies above it.
By their numbers in this assay, from the lowest: compounds 3 and 1 (each within the scatter of the next); then compound 2.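

In this assay the change to 2-fluorophenyl in place of 4-(trifluoromethyl)phenyl on a saturated chain carbon bound to an amine nitrogen in a ring gives a 4.6-fold lower number from compound 2 to compound 3 (0.66 log units; beyond the scatter) and so lies beyond the scatter. This shows that the end of the molecule left untouched by a 3.0-fold higher number from compound 1 to compound 2 (0.48 log units; beyond the scatter) also shifts the number, here downward, with the 3-cyanophenyl arm held constant. No independent measurement is available to explain this shift.

Among the compounds shown here, the single step replaces one whole substituted ring with another, so it cannot separate the loss of the trifluoromethyl group from the arrival of the fluorine, and an unsubstituted phenyl or a 4-fluorophenyl at this place would be needed to tell them apart. The compounds shown also leave open whether the 2-fluorophenyl group would give a step of similar size on the 2-cyanophenyl arm, and how a chlorine or a methoxy group in place of the fluorine would read.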